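The source may report more compounds than this note shows. Statements on the series, on what has been measured and on what is new or still open speak of the compounds shown alone.

Compound 1 `Nc1nc(-c2ccccc2)nc2sc(-c3ccccc3)nc12` is the parent of this small set. In an assay on CHO cells for displacement of a labelled ligand from adenosine receptor A1 (Homo sapiens), read by scintillation counting, with a stated time of 3 h (on this read-out higher numbers stand for weaker inhibition and lower numbers for stronger inhibition), compound 1 gives 148 nM. Compound 2 `Nc1nc(-c2cccc(CO)c2)nc2sc(-c3ccccc3)nc12` carries hydroxymethyl in place of hydrogen on an aromatic carbon on the same core, and in this assay compound 2 gives 32 nM, a step of a 4.6-fold lower number from compound 1 to compound 2 (0.67 log units; beyond the scatter). Compound 3 `Nc1nc(-c2ccccc2)nc2sc(-c3ccco3)nc12` instead changes the core itself, by furan-2-yl in place of phenyl on an aromatic carbon, and in this assay compound 3 gives 33 nM, a step of a 4.5-fold lower number from compound 1 to compound 3 (0.65 log units; beyond the scatter). Compound 2 and compound 3 thus stand within the scatter of each other.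

Compound 4 `Nc1nc(-c2ccc(CO)cc2)nc2sc(-c3ccco3)nc12` has not been measured. It differs from compound 3 by hydroxymethyl in place of hydrogen on an aromatic carbon. Among the measured compounds shown here, this is the same kind of change as the one from compound 1 to compound 2, but not the same: there the hydroxymethyl sits meta to a large group, here para to a large group, and the two cores differ by furan-2-yl in place of phenyl on an aromatic carbon. Starting from compound 3, a step of about a 2.5-fold lower number from compound 3 to compound 4 (0.40 log units; beyond the scatter) is expected in this assay because a 4.6-fold lower number from compound 1 to compound 2 (0.67 log units; beyond the scatter) was seen for the same kind of change. The place and core are not identical, so the expected step is kept smaller than that one. For compound 4 an inhibition constant near 13 nM is estimated, expected to fall between 5 nM and 40 nM.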

Compound 4, inhibition constant: 77.7 nM
The estimate for compound 4 lay 6.0-fold (0.78 log units) below the measured number, outside the stated range (above it).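

Hydroxymethyl in place of hydrogen gave a 2.4-fold higher number from compound 3 to compound 4 (0.37 log units; beyond the scatter) in this assay, so the lower number seen on the core of compound 1 did not carry over to the core of compound 3. Set side by side, the two steps run in opposite directions and differ: the same change on two cores in this assay, a 4.6-fold lower number (0.67 log units; beyond the scatter) from compound 1 to compound 2 and a 2.4-fold higher number (0.37 log units; beyond the scatter) from compound 3 to compound 4, 11-fold (1.04 log units) apart, beyond the scatter of two such steps What this does not show is whether the core or the place of the group decides the outcome: compound 4 carries the hydroxymethyl para to a large group, compound 2 carries it at a different place on the ring, and the two steps therefore change core and place together.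

Left open is how hydroxymethyl behaves at the place seen in compound 2 on the core of compound 3, and at the place seen in compound 4 on the core of compound 1, the comparisons that would separate the two. Also open, on these data alone, is whether a methoxy or an aminomethyl group at these places would follow compound 2 or compound 4.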